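A few compounds are considered here, and "the series" means these few. Any claim that something is new, unique, unknown or untested is made for them only; others in the source may bear on it.

Working notes on the series. Compound 1 `CC(O)(CSc1ccc(F)cc1)C(=O)Nc1cccc(S(F)(F)(F)(F)F)c1` and compound 2 `CC(O)(CSc1cccc(C(F)(F)F)c1)C(=O)Nc1cccc(S(F)(F)(F)(F)F)c1` share one core; compound 2 differs from compound 1 by 3-(trifluoromethyl)phenyl in place of 4-fluorophenyl on a sulfur. In a functional assay on VCaP cells (Homo sapiens) for antiproliferative activity, read by propidium iodide staining, with a stated time of 96 h (a lower number here means a stronger inhibitor, a higher number a weaker inhibitor), compound 1 gives 21900 nM, and compound 2 gives 20200 nM. That change made a 1.1-fold lower number from compound 1 to compound 2 (0.04 log units; within the scatter), so the two values cannot be told apart.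

Compound 3 `CC(O)(CS(=O)(=O)c1ccc(F)cc1)C(=O)Nc1cccc(S(F)(F)(F)(F)F)c1` stands on a different core, and the difference between the two cores is not broken down here. In this assay compound 3 gives 37900 nM. Against compound 1 and compound 2 this is the highest of the three numbers, yet each gap is within the scatter, so no order among the three is claimed.

Compound 4 `CC(O)(CS(=O)(=O)c1cccc(C(F)(F)F)c1)C(=O)Nc1cccc(S(F)(F)(F)(F)F)c1` is not yet measured. It differs from compound 3 by 3-(trifluoromethyl)phenyl in place of 4-fluorophenyl on a sulfonyl sulfur. This is the same kind of change as that from compound 1 to compound 2, though the surroundings differ: in compound 1 the group sits on a sulfur, whereas in compound 3 it sits on a sulfonyl sulfur whose other neighbours are a saturated chain carbon. In this assay compound 4 is expected to show a step of about a 1.1-fold lower number from compound 3 to compound 4 (0.03 log units; within the scatter), close to the earlier one, because compound 3 gives 37900 nM and the same change made a 1.1-fold lower number from compound 1 to compound 2 (0.04 log units; within the scatter), with a single prior instance to rest on. The estimate for compound 4 in this assay is 35000 nM, with a range from 15000 nM to 80000 nM.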

Compound 4, half-maximal inhibitory concentration: 35500 nM
Compound 4: the middle estimate sits 1.0-fold (0.01 log units) below what was measured; the measured number falls inside the stated range.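

In this assay, 3-(trifluoromethyl)phenyl in place of 4-fluorophenyl on a sulfonyl sulfur gives a 1.1-fold lower number from compound 3 to compound 4 (0.03 log units; within the scatter), so the values on the two sides of this step cannot be told apart. Set beside the earlier step on a sulfur, the change carries from one core to the other with no readable difference: the same change on two cores in this assay, a 1.1-fold lower number (0.04 log units; within the scatter) from compound 1 to compound 2 and a 1.1-fold lower number (0.03 log units; within the scatter) from compound 3 to compound 4, 1.0-fold (0.01 log units) apart, within the scatter of two such steps. Among these compounds, this shows only that the exchange between these two groups leaves no readable mark on the number in either pair; it rests on two pairs in a single assay, neither step lies beyond the scatter, and it does not show that the change would behave alike on any other core or that a change with a readable step would carry over in the same way.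

The compounds shown leave open whether any step beyond the scatter can be obtained at this place at all, for example with an amine, a carboxylic acid or a longer chain on the sulfur or sulfonyl sulfur in place of these two aromatic groups. They also leave open whether the sulfur and sulfonyl cores would stay indistinguishable once such a group is carried on both.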